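Fluoro placement on the fused ring in cyclopropyl amides

The compounds below may be only part of what the source reports. "The series", "measured", "known", "first", "only" and "open" are said of these compounds alone.

Of the compounds shown here, three have been measured in a functional assay on the whole organism with Mus musculus as the target, at a dose of 100 mg/kg by the intraperitoneal route; on this read-out higher numbers stand for more inhibition at the one dose given (going by the name of the read-out) and lower numbers for less inhibition. Compound 1 `O=C(/C=C1\CCc2c(F)cc(F)cc21)NC1CC1` gives 100% in this assay, and compound 2 `O=C(/C=C1\CCc2c(F)cccc21)NC1CC1` gives 100%. Compound 3 `CCNC(=O)/C=C1\CCc2c(F)cc(F)cc21` gives 67% in this assay. Compound 2 stands level with compound 1 at the digits shown, the two together the highest of the three numbers; the nearest neighbour of compound 2 is compound 1, with no change at the digits printed from compound 1 to compound 2 (within the scatter), and the furthest is compound 3, with a number 33 percentage points lower from compound 1 to compound 3 (beyond the scatter) from compound 1.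

The next compound is compound 4 `O=C(/C=C1\CCc2c(F)ccc(F)c21)NC1CC1`. Relative to compound 2 the change is fluoro in place of hydrogen on an aromatic carbon, on a six-membered aromatic ring of carbon only within the fused system of two rings; the cyclopropyl amide is kept. For the measured compounds named here, the step that bears on this is the one from compound 1 to compound 2, a fluoro-for-hydrogen exchange on the same aromatic ring, which gave no change at the digits printed from compound 1 to compound 2 (within the scatter). The step to compound 3 concerns the amide nitrogen and does not bear here. No step beyond the scatter is therefore expected in this assay.

Compound 4 is expected to give about 95% in this assay, within 80% to 100%. The expected step is a number 5 percentage points lower from compound 2 to compound 4 (within the scatter), because no change at the digits printed from compound 1 to compound 2 (within the scatter) showed no effect of a fluoro at a ring position.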

Compound 4, a percentage reported as inhibition, in the whole organism at one dose (the size of the read-out at that dose, not a potency): 100%
Compound 4: middle estimate off by 5 percentage points, on the low side; measured number inside the range.
By their numbers in this assay, from the lowest: compound 3; then compounds 1, 2 and 4 (each within the scatter of the next).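

With this step, the fluoro that enters on the aromatic carbon para to a fluoro group, ortho to a fused ring and meta to a fused ring leaves this assay with no change at the digits printed from compound 2 to compound 4 (within the scatter) and the cyclopropyl amide unchanged. The earlier fluoro exchange, read in the other direction, concerned a different aromatic carbon, so the series now holds two ring placements of a second fluoro on compound 2 with no step beyond the scatter: compound 1 gives 100% and compound 4 gives 100% at the digits printed. No measurement on hand accounts for this lack of response, and the data give no cause for it.

On these data alone, all three cyclopropyl amides share one printed value at a single dose, so any difference among them that this one dose does not show remains open, and a dose series would be needed to separate them. Also open, as far as these compounds go, are a larger or different group at this carbon, such as chloro, methoxy or an amine, and whether the ethyl amide of compound 3 responds in the same way to this fluoro.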